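Replacing methoxy with methyl: expected effect on compound 3

The compounds below may be only part of what the source reports. "The series", "measured", "known", "first", "only" and "open" are said of these compounds alone.

Measured in a physicochemical assay for acid dissociation:
compound 1 `COc1cnc(C[S+]([O-])c2nc3cc(OC(F)F)ccc3[nH]2)cc1OC`: 8.03
compound 2 `COc1cnc(C[S+]([O-])c2nc3cc(OC(F)F)ccc3[nH]2)c(C)c1OC`: 8.35

Of the two measured compounds, compound 2 stands highest at 8.35 in this assay. Next is compound 3 `COc1c(C)cnc(C[S+]([O-])c2nc3cc(OC(F)F)ccc3[nH]2)c1C`, with methyl in place of methoxy on an aromatic carbon. Going by the values given here, one measured step bears on this, and only indirectly: a number 0.32 log units higher from compound 1 to compound 2 (beyond the scatter), a modest change that put methyl in place of hydrogen. Among the compounds with values here, no measured step replaces methoxy, so a small upward move at most is expected, none beyond the scatter. The expected change is a number 0.10 log units higher from compound 2 to compound 3 (within the scatter) in this assay. For compound 3 the estimated value is 8.45, with an expected range from 8.15 to 8.75.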

Compound 3, acid dissociation constant: 8.23
For compound 3 the middle estimate is 0.22 log units above the measured one; the range from low to high includes it.
By their numbers in this assay, from the lowest: compounds 1, 3 and 2 (each within the scatter of the next, the first and the last beyond it).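

In this assay, exchanging the methoxy group for a methyl group, two atoms from the ring nitrogen, gives a number 0.12 log units lower from compound 2 to compound 3 (within the scatter) and so cannot be told apart from no change. The exchange thus removes a hydrogen-bond acceptor and a heavy atom here without a shift beyond the scatter. No measurement on hand explains this reading.

From the compounds shown here alone, whether an amine, a carboxylic acid or a longer chain at this carbon would move the number beyond the scatter stays open. So does the outcome of the same exchange at the remaining methoxy group.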